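A few compounds are considered here, and "the series" means these few. Any claim that something is new, unique, unknown or untested is made for them only; others in the source may bear on it.

Measured in an ADME assay on Vero 76 cells (Chlorocebus sabaeus) for cytotoxicity, read by crystal violet staining, with a stated time of 96 h; a lower number here means that less compound is tolerated, a higher number that more compound is tolerated:
- compound 1 `CCCCc1ccc(NC(=S)Nc2cccc(C(F)(F)F)c2)c(C)c1`: 18000 nM
- compound 2 `CCNC(=S)Nc1cccc(C(F)(F)F)c1`: > 100000 nM

Compound 2 has no exact number, only a limit: the limit of > 100000 nM in this assay, at which 1 of the 2 values shown sits. Compound 3 `Fc1ccccc1NC(=S)Nc1cccc(C(F)(F)F)c1` follows from compound 2 by 2-fluorophenyl in place of ethyl on an amide-type nitrogen, with 2-fluorophenyl in place of ethyl on an amide-type nitrogen. For the measured compounds named here, no measured step bears directly on this change. Going by the values given here, the only exact value available is that of compound 1 at 18000 nM, and this is the basis for expecting a move towards less compound tolerated, beyond the scatter. The expected step is an at least 2.5-fold lower number from compound 2 to compound 3 (0.39 log units; beyond the scatter). For compound 3 the estimate in this assay is 40000 nM, with an expected range of 15000 nM to 100000 nM.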

Compound 3, half-maximal cytotoxic concentration: 64000 nM
Compound 3: the middle estimate sits 1.6-fold (0.20 log units) below what was measured; the measured number falls inside the stated range.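

In this assay, 2-fluorophenyl in place of ethyl on an amide-type nitrogen gives an at least 1.5-fold lower number from compound 2 to compound 3 (0.19 log units; that floor lies within the scatter). Compound 3, at 64000 nM, gives this place an exact number with a six-membered aromatic ring on that nitrogen. Compound 2 carries only a limit, so the true size of the step stays unknown: the limit of > 100000 nM in this assay, at which 1 of the 3 values shown sits.

The compounds shown leave open whether the ring or its fluorine accounts for the number of compound 3. A plain phenyl or a chain ending in an amine on the same nitrogen would bear on this.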